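The source may hold more compounds than are shown below. What is called first, only, known or untested is meant among the compounds shown, and "the series" means these compounds.

Measured compounds:
- compound 1, `CCC1C(=O)N(C)c2cnc(-n3ccc4cc(C(N)=O)ccc43)nc2N1c1ccn(C)n1`: "not active" (no number reported)
- compound 2, `CCCCNS(=O)(=O)c1ccc(Nc2ncc3c(n2)N(c2ccn(C)n2)C(CC)C(=O)N3C)cc1`: 3750 nM

In a functional assay on Huh-7 cells (Homo sapiens) for antiproliferative activity, read by CCK-8 assay, with a stated time of 72 h (on this read-out higher numbers stand for weaker inhibition of growth and lower numbers for stronger inhibition of growth), compound 1 is recorded as "not active" (no number reported), so no single number places it on the scale. For the measured compounds named here, compound 2 reaches 3750 nM in this assay, but no step between compound 1 and compound 2 is drawn, and their shared core carries different substituents, so their two values are simply noted side by side.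

Compound 3, `CCCNC(=O)c1ccc2c(ccn2-c2ncc3c(n2)N(c2ccn(C)n2)C(CC)C(=O)N3C)c1`, is not yet measured in this assay. It differs from compound 1 in one place: propyl in place of hydrogen on an amide-type nitrogen. Going by the values given here, no step of this kind has been measured, so there is nothing to calibrate the direction of the change. Given that compound 1 shows "not active" (no number reported) in this assay, the expectation is for a small step at best, if any beyond the scatter, and a fair chance that again no number is reported. For compound 3 in this assay the estimate is 6000 nM, with a range from 1500 nM to 30000 nM.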

Compound 3, concentration for 50% growth inhibition: 7280 nM
Compound 3: middle estimate off by 1.2-fold (0.08 log units), on the low side; measured number inside the range.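

In this assay compound 1 stands as "not active" (no number reported) and compound 3 at 7280 nM so no step can be read between these two compounds. Nothing at hand offers an explanation for the result. The compounds shown leave open how far the change from carbamoyl to propylcarbamoyl moves growth inhibition.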